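Methoxy for fluoro on the aryl ketone

This account rests on a few compounds, and the source may have more. Where it says the series, first, only, none or still open, it means among the compounds named here.

Compound 1 `O=C(CSc1nc2ccccc2[nH]1)c1ccc(F)cc1` is recorded in a functional assay on HT-29 cells (Homo sapiens) for inhibition, read by flow cytometry, tested at 10 uM (a higher number here means more inhibition at the concentration tested (going by the name of the read-out), a lower number less inhibition), only as "not active" (no number reported), so no single number fixes where it stands. Compound 2 `COc1ccc(C(=O)CSc2nc3ccccc3[nH]2)c(OC)c1OC`, the more heavily methoxylated analogue, gives 50.1% in this assay. Compound 3 `COc1ccc(C(=O)CSc2nc3ccccc3[nH]2)cc1` is the single-methoxy analogue, not yet measured; from compound 1 it differs by methoxy in place of fluoro on an aromatic carbon. Within the data shown here, with compound 1 lacking a number, no step can be sized; an upward move into measurable inhibition is expected, likely smaller than what compound 2 shows. Compound 3 is expected to give 25% in this assay, within 0% to 55%.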

Compound 3, a percentage reported as inhibition, at one concentration (the size of the read-out at that concentration, not a potency): 52.6%
Beside the measured number, compound 3's estimate is 27.6 percentage points below it, within the range that was stated.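

No step can be read between compound 1 and compound 3: in this assay compound 1 stands only as "not active" (no number reported) without a number. The compounds shown leave open how large the change from fluoro to methoxy is. No evidence bearing on the result is available.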